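The compounds below may be only part of what the source reports. "The series", "measured", "known", "first", "only" and "open" are said of these compounds alone.

Working notes on the series, read in a functional assay on DU-145 cells (Homo sapiens) for inhibition, read by trypan blue exclusion, with a stated time of 96 h; on this read-out lower numbers stand for stronger inhibition of growth and higher numbers for weaker inhibition of growth. Compound 1 `O=C(O)c1ccc(C(=O)/C(=C\c2ccc(Cl)c([N+](=O)[O-])c2)SCc2ccc(Cl)cc2)cc1` gives 1000 nM and compound 2 `O=C(O)c1ccc(C(=O)/C(=C\c2ccc(Cl)c([N+](=O)[O-])c2)SCc2ccc(F)cc2)cc1` gives 1000 nM. For the measured compounds named here, these two stand level, together the lowest of the three numbers so far. Compound 3 `CC(=O)Nc1ccc(/C=C(/SCc2ccc(F)cc2)C(=O)c2ccc(C(=O)O)cc2)cc1[N+](=O)[O-]` gives 10000 nM.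

Compound 4 `COc1ccc(/C=C(/SCc2ccc(F)cc2)C(=O)c2ccc(C(=O)O)cc2)cc1O` is still unmeasured. Its change is 3-hydroxy-4-methoxyphenyl in place of 4-chloro-3-nitrophenyl on a double-bonded chain carbon bound to a double-bonded chain carbon, which is 3-hydroxy-4-methoxyphenyl in place of 4-chloro-3-nitrophenyl on a double-bonded chain carbon bound to a double-bonded chain carbon.

The halogen swap gives no change at the digits printed from compound 1 to compound 2 (within the scatter), but it lies elsewhere in the molecule and says little here. Going by the values given here, the closer guide is a 10-fold higher number from compound 2 to compound 3 (1.00 log units; beyond the scatter), with acetamido in place of chloro, the only measured change within the group that leaves. On these data alone, all three measured compounds carry the nitro group, so the effect of losing it is unknown and the estimate stays wide.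

Among the compounds with values here, with that step as the only guide, the expected result is a higher number, probably a smaller rise than that one, and the expected step is a 4.0-fold higher number from compound 2 to compound 4 (0.60 log units; beyond the scatter). For compound 4 the estimated value in this assay is 4000 nM, with an expected range from 1000 nM to 20000 nM.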

Compound 4, concentration for 50% growth inhibition: 10000 nM
Compound 4: the middle estimate sits 2.5-fold (0.40 log units) below what was measured; low and high end bracket the measured number.
By their numbers in this assay, from the lowest: compounds 1 and 2 (each within the scatter of the next); then compounds 3 and 4 (each within the scatter of the next).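

In this assay, 3-hydroxy-4-methoxyphenyl in place of 4-chloro-3-nitrophenyl on a double-bonded chain carbon bound to a double-bonded chain carbon gives a 10-fold higher number from compound 2 to compound 4 (1.00 log units; beyond the scatter), the first step shown in which the nitro group leaves along with the chloro. Compound 3, which keeps the nitro group, prints 10000 nM and compound 4, which has lost it, prints 10000 nM, so keeping the nitro group does not by itself hold the lower number seen for compound 2. No measurement at hand bears on why the number rises with this change.

The compounds shown leave open whether the chloro or the nitro group counts for more here, as both leave together in compound 4. An amine or a nitrile in place of the nitro group, with the chloro kept, would separate the two.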